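A few compounds are considered here, and "the series" means these few. Any claim that something is new, unique, unknown or untested is made for them only; others in the source may bear on it.

Measured compounds:
- compound 1, `O=[N+]([O-])c1cc(OCc2ccccc2)ccc1CNc1cc(C(F)(F)F)cc2[nH]ncc12`: 10%
- compound 2, `O=[N+]([O-])c1cc(Cl)ccc1CNc1cc(C(F)(F)F)cc2[nH]ncc12`: 50%
- compound 3, `CC(C)n1ncc2c(NCc3ccccc3[N+](=O)[O-])cc(C(F)(F)F)cc21`: 7%

In an assay for inhibition of Indoleamine 2,3-dioxygenase 1 (Homo sapiens), with stated times of 10 min and 60 min, tested at 10 uM (on this read-out lower numbers stand for a weaker effect and higher numbers for a stronger effect at the one concentration tested), compound 3 gives 7%, the lowest of the three numbers. Compound 1 gives 10%, which sits within the usual scatter of compound 3, so the two cannot be told apart. Compound 2 gives 50%, and this number lies beyond the scatter above compound 3.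

Compound 4, `O=[N+]([O-])c1ccccc1CNc1cc(C(F)(F)F)cc2[nH]ncc12`, has not yet been measured in this assay. It arises from compound 3 by one change: hydrogen in place of isopropyl on an aromatic nitrogen. For the measured compounds named here, the only measured step, a number 40 percentage points higher from compound 1 to compound 2 (beyond the scatter), concerns a chloro in place of benzyloxy on an aromatic carbon elsewhere in the molecule, so it does not bear directly on the change at the aromatic nitrogen. Going by the values given here, no measured pair shows what removing the isopropyl does. Compound 2, which also carries hydrogen on that nitrogen, reaches 50%, while compound 1, with the same hydrogen but a benzyloxy group, gives 10%; compound 4 carries neither substituent, so these two numbers only bracket the possibilities.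

The step of a number 18 percentage points higher from compound 3 to compound 4 (beyond the scatter) is therefore expected to be modest and uncertain. For compound 4 the estimate is 25%, with a range from 3% to 55%.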

Compound 4, a percentage reported as inhibition, at one concentration (the size of the read-out at that concentration, not a potency): 35%
Compound 4: the middle estimate sits 10 percentage points below what was measured; low and high end bracket the measured number.
By their numbers in this assay, from the lowest: compounds 3 and 1 (each within the scatter of the next); then compound 4; then compound 2.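

For the compounds shown here, replacing isopropyl with hydrogen on the aromatic nitrogen gives a number 28 percentage points higher from compound 3 to compound 4 (beyond the scatter) in this assay, the first direct comparison at this position, and it shows that the two are not interchangeable there. Compound 4 also adds a reference point on the aromatic carbon that varied earlier: there is a number 25 percentage points higher from compound 1 to compound 4 (beyond the scatter) and a number 15 percentage points lower from compound 2 to compound 4 (beyond the scatter), so in this set of three, hydrogen on that carbon ranks below chloro and above benzyloxy. No supporting measurement is available to explain why these numbers differ.

Compound 3 is the only compound shown with isopropyl, and it has hydrogen on the aromatic carbon, so it remains open whether the same step would appear with chloro or benzyloxy there. Also open, from the compounds shown here alone, is what a methyl group or a longer chain ending in an amine would give on the aromatic nitrogen, and whether a nitrile or a carboxylic acid on the aromatic carbon would give a number above or below that of chloro.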